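Removing a methyl from the amine of compound 2

The source may report more compounds than this note shows. Statements on the series, on what has been measured and on what is new or still open speak of the compounds shown alone.

Compound 2 `CC(CC(C)(C)C)Oc1cccc2ccc(N(C)C)nc12` gives only a limit in an assay on cells with melanin-concentrating hormone receptor 1 (Homo sapiens) as the target, read by radioligand binding (on this read-out higher numbers stand for weaker inhibition and lower numbers for stronger inhibition), namely > 2000 nM. Compound 1 `CC(CC(C)(C)C)Oc1cccc2ccc(N3CCCCC3)nc12` likewise gives a limit in this assay, > 2000 nM. The step that the two limits leave unreadable from compound 1 to compound 2 is unreadable; the limit of > 2000 nM in this assay, at which 2 of the 2 values shown sit, is all the two values show. Compound 3 `CNc1ccc2cccc(OC(C)CC(C)(C)C)c2n1` differs from compound 2 by hydrogen in place of methyl on a nitrogen on an aromatic ring. Going by the values given here, no measured step bears on this change, and compound 2 sits at the limit. Compound 3 is expected to stay near that limit, the step that the limit leaves unreadable from compound 2 to compound 3 meaning no change beyond the scatter. Compound 3 is estimated at 3000 nM, between 1000 nM and 10000 nM.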

Compound 3, half-maximal inhibitory concentration: 310 nM
Compound 3: the middle estimate sits 9.7-fold (0.99 log units) above what was measured; measured number below the stated range.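

Of the three amino groups on this aromatic carbon, only methylamino gives a measured number in this assay: compound 3 gives 310 nM. Hydrogen in place of methyl on the nitrogen gives an at least 6.4-fold lower number from compound 2 to compound 3 (0.80 log units; beyond the scatter), and methylamino in place of piperidin-1-yl gives an at least 6.4-fold lower number from compound 1 to compound 3 (0.80 log units; beyond the scatter). Both steps are minimum sizes only, because the values they start from are limits: the limit of > 2000 nM in this assay, at which 2 of the 3 values shown sit.

As far as these compounds go, it remains open whether an unsubstituted amino group or ethylamino on this carbon would give a lower number than methylamino. From the compounds shown here alone, it is also open whether the step from dimethylamino to methylamino holds with a shorter chain on the oxygen.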